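Adding a methyl to the bromophenyl ring of compound 3

The compounds below may be only part of what the source reports. "The series", "measured", "known", "first", "only" and "open" are said of these compounds alone.

Of the compounds shown here, three sharing one core have been tested in a functional assay on MV4-11 cells (Homo sapiens) for inhibition, with a stated time of 120 h, tested at 10 uM; on this read-out lower numbers stand for less inhibition and higher numbers for more inhibition at the one concentration tested (going by the name of the read-out). Compound 1 `Cc1n[nH]c2ccc(-c3nc4cnc(N5CCN(C)CC5)cn4c3Nc3ccc(F)cc3)cc12` gives 0%. Compound 2 `Cc1n[nH]c2ccc(-c3nc4cnc(N5CCN(C)CC5)cn4c3Nc3ccccc3Cl)cc12` gives 58.1%, and compound 3 `Cc1n[nH]c2ccc(-c3nc4cnc(N5CCN(C)CC5)cn4c3Nc3ccc(Br)cc3)cc12` gives 83%, the highest of the three; its nearest neighbour is compound 2, and the gap is shown by a number 24.9 percentage points higher from compound 2 to compound 3 (beyond the scatter), while the gap to compound 1 is shown by a number 83 percentage points higher from compound 1 to compound 3 (beyond the scatter).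

Compound 4 `Cc1cc(Br)ccc1Nc1c(-c2ccc3[nH]nc(C)c3c2)nc2cnc(N3CCN(C)CC3)cn12` is not yet measured. It differs from compound 3 by a single change: methyl in place of hydrogen on an aromatic carbon.

Going by the values given here, no measured step adds or removes a methyl. The steps that touch the same ring all swap halogens, as in a number 58.1 percentage points higher from compound 1 to compound 2 (beyond the scatter) and a number 83 percentage points higher from compound 1 to compound 3 (beyond the scatter), and each is large, so this ring clearly matters; yet they say nothing about a methyl as such. Compound 3 already sits near the top of the scale, which leaves little room above it. The expected outcome is therefore a step of a number 5 percentage points lower from compound 3 to compound 4 (within the scatter), within the scatter, in no clear direction. Compound 4 is estimated at 78%, in the range 50% to 95%.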

Compound 4, a percentage reported as inhibition, at one concentration (the size of the read-out at that concentration, not a potency): 59.4%
Estimate against measurement, compound 4: 18.6 percentage points above; the measured number falls inside the stated range.
By their numbers in this assay, from the lowest: compound 1; then compounds 2 and 4 (each within the scatter of the next); then compound 3.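

In this assay, going by these compounds alone, the step of a number 23.6 percentage points lower from compound 3 to compound 4 (beyond the scatter) is the first to change this ring without swapping a halogen, and it shows that a lone methyl, ortho to a large group, can lower the number even with the bromo group kept. The result a number 1.3 percentage points higher from compound 2 to compound 4 (within the scatter) puts the 4-bromo-2-methylphenyl and 2-chlorophenyl rings level, while a number 59.4 percentage points higher from compound 1 to compound 4 (beyond the scatter) shows that the methyl-bearing ring still stands well clear of the 4-fluorophenyl ring. Nothing given here explains the effect of the methyl.

From the compounds shown here alone, it remains open whether a methoxy group or an amine at the same place would behave like the methyl. Going by these compounds, it is also open whether a methyl there would have the same effect on a ring bearing chloro or fluoro instead of bromo.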